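This account rests on a few compounds, and the source may have more. Where it says the series, first, only, none or still open, it means among the compounds named here.

In a functional assay on MCF7 cells (Homo sapiens) for inhibition, read by colorimetric assay and MTT assay, with a stated time of 72 h (a higher number here means a weaker inhibitor, a lower number a stronger inhibitor), compound 1 `C=CCCCCOc1ccccc1-c1cnc(OCCCC=C)n1C` gives 7000 nM, compound 2 `C=CCCCCCOc1ncc(-c2ccccc2OCCCCC=C)n1C` gives 63000 nM, and compound 3 `CCCCOc1ncc(-c2ccccc2OC)n1C` gives 55000 nM. Compound 3 thus lies within the scatter of compound 2 and well above compound 1 on this scale, among the weaker inhibitors of the set.

Compound 4 `CCCCCCOc1ncc(-c2ccccc2OC)n1C` differs from compound 3 by one change: ethyl in place of hydrogen on a saturated chain carbon, four bonds along the chain from an oxygen on an aromatic ring.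

For the measured compounds named here, only one measured step bears on this change. It also extends a chain, with but-3-en-1-yl in place of vinyl, and it amounts to a 9.0-fold higher number from compound 1 to compound 2 (0.95 log units; beyond the scatter). That step points towards a weaker inhibitor, but it is a single example, and it starts from a much lower number than compound 3 does. Its end point, compound 2 at 63000 nM, also sits level with compound 3. A much smaller shift in the same direction therefore seems likely, and the expected change is a 1.4-fold higher number from compound 3 to compound 4 (0.13 log units; within the scatter), which would not clearly leave the scatter. Compound 4 is estimated at 75000 nM, with an expected range from 25000 nM to 200000 nM.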

Compound 4, half-maximal inhibitory concentration: 27000 nM
For compound 4 the middle estimate is 2.8-fold (0.44 log units) above the measured one; low and high end bracket the measured number.
By their numbers in this assay, from the lowest: compound 1; then compound 4; then compounds 3 and 2 (each within the scatter of the next).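

In this assay, ethyl in place of hydrogen on a saturated chain carbon, four bonds along the chain from an oxygen on an aromatic ring, gives a 2.0-fold lower number from compound 3 to compound 4 (0.31 log units; beyond the scatter). For the compounds shown here, this is the first sign that adding to a chain can move these compounds towards a stronger inhibitor, whereas the only earlier chain step, a different change at a different place, went the other way, with a 9.0-fold higher number from compound 1 to compound 2 (0.95 log units; beyond the scatter). Chain growth therefore has no single direction across the steps shown, and the evidence here offers no explanation for the difference.

The compounds shown leave open whether the trend from hydrogen to ethyl would continue with a longer chain such as octyl at this position, or whether an amine or a carboxylic acid in place of the ethyl would keep the gain. They also leave open whether the same ethyl change would have the same effect on the core of compound 1, which carries different chains.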